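The source may report more compounds than this note shows. Statements on the series, on what has been measured and on what is new or still open speak of the compounds shown alone.

Compound 1 `O=c1cc(I)n([C@@H]2O[C@H](CO)[C@@H](O)[C@H]2O)c(=O)[nH]1` is a nucleoside carrying an iodo group on its base. In a functional assay on MCF7 cells (Homo sapiens) for antiproliferative activity, read by WST assay, with a stated time of 3 days (a lower number here means a stronger inhibitor, a higher number a weaker inhibitor), compound 1 gives only a limit of the assay, > 50000 nM, and not a number. Compound 2 `CNc1cc(=O)[nH]c(=O)n1[C@@H]1O[C@H](CO)[C@@H](O)[C@H]1O`, which differs from it by methylamino in place of iodo on an aromatic carbon, likewise sits at a limit: in this assay compound 2 gives > 50000 nM. The step that the two limits leave unreadable from compound 1 to compound 2 is therefore unreadable, since (the limit of > 50000 nM in this assay, at which 2 of the 2 values shown sit). Compound 3 `CC(=O)OC[C@H]1O[C@@H](n2c(I)cc(=O)[nH]c2=O)[C@H](O)[C@@H]1O` keeps the iodo base and differs from compound 1 only at the sugar: acetyl in place of hydrogen on an oxygen on a saturated carbon. Going by the values given here, no measured step touches this oxygen, so nothing here predicts the direction of the change. Given that compound 1 already shows only a limit, compound 3 is expected to give a similar reading, with an estimated step that the limit leaves unreadable from compound 1 to compound 3 amounting to none beyond the scatter. Compound 3 is thus estimated at 60000 nM, between 15000 nM and 200000 nM.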

Compound 3, half-maximal inhibitory concentration: 4400 nM
Beside the measured number, compound 3's estimate is 14-fold (1.13 log units) above it; the whole stated range lies above it.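

With the iodo base kept, acetyl in place of hydrogen on an oxygen on a saturated carbon brings an at least 11-fold lower number from compound 1 to compound 3 (1.05 log units; beyond the scatter) in this assay, so this sugar oxygen is a place where a single change moves the reading beyond the scatter. Compound 3 is the only one of the three compounds shown that gives a number, while the step between compound 1 and compound 2 at the base cannot be read. The full size of the gain stays unknown because the starting point is a limit and not a number: the limit of > 50000 nM in this assay, at which 2 of the 3 values shown sit.

The compounds shown leave open whether acetyl is special here or whether a longer chain such as butyryl, or a benzoyl group, on the same oxygen would do the same. They also leave open whether hydroxymethyl to acetoxymethyl would bring a similar change on the methylamino base of compound 2.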